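The source may hold more compounds than are shown below. What is called first, only, known or untested is meant among the compounds shown, and "the series" means these compounds.

Three compounds share one core and differ only in the group carried on an aromatic carbon of its five-membered ring. Compound 1 `Cc1ccc(-c2c[nH]c3ncc(-c4cnn(C)c4)cc23)cc1` gives 7000 nM in a physicochemical assay for solubility, read by LC-MS, in phosphate buffer, measured as thermodynamic solubility, with a stated time of 24 h, at pH 7.4 (a higher number here means a more soluble compound, a lower number a less soluble compound), which is the second highest of the three numbers. Compound 2 `COc1ccc(-c2c[nH]c3ncc(-c4cnn(C)c4)cc23)cc1` gives 5000 nM in this assay, and the step of a 1.4-fold lower number from compound 1 to compound 2 (0.15 log units; within the scatter) lies within the scatter. Compound 3 `Cn1cc(-c2cnc3[nH]cc(-c4ccc(C(=O)O)cc4)c3c2)cn1` gives 850000 nM in this assay; the steps of a 120-fold higher number from compound 1 to compound 3 (2.08 log units; beyond the scatter) and a 170-fold higher number from compound 2 to compound 3 (2.23 log units; beyond the scatter) are both large.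

Compound 4 `Cn1cc(-c2cnc3[nH]cc(C4CCNCC4)c3c2)cn1` has not been measured. It differs from compound 1 by piperidin-4-yl in place of 4-methylphenyl on an aromatic carbon. Among the measured compounds shown here, the two large measured steps put carboxy in place of methyl or methoxy, and no measured step exchanges the whole 4-methylphenyl, so the guide is indirect. Still, both large steps show that exchanging this group for one of a different kind raised the number strongly, and a large rise in this assay is expected, of roughly a 71-fold higher number from compound 1 to compound 4 (1.85 log units; beyond the scatter). Compound 4 is therefore estimated at 500000 nM, with a range from 100000 nM to 2000000 nM.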

Compound 4, solubility: 770000 nM
Compound 4: middle estimate off by 1.5-fold (0.19 log units), on the low side; measured number inside the range.
By their numbers in this assay, from the lowest: compounds 2 and 1 (each within the scatter of the next); then compounds 4 and 3 (each within the scatter of the next).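

In this assay, piperidin-4-yl in place of 4-methylphenyl gives a 110-fold higher number from compound 1 to compound 4 (2.04 log units; beyond the scatter), so this position on the five-membered ring can take a change of the whole group, not only of what the six-membered aromatic ring carries. The rise also does not depend on a carboxy group: compound 4, at 770000 nM, lies within the scatter of compound 3, at 850000 nM, although one carries a non-aromatic ring with a nitrogen and the other an aromatic ring of carbon only with a carboxy group. No measurement here gives a reason for this rise.

The compounds shown do not separate the loss of the aromatic ring from the arrival of the ring nitrogen. Cyclohexyl, which has the non-aromatic ring without the nitrogen, and 4-aminophenyl, which has an amine on the aromatic ring, would pull these two changes apart.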